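A few compounds are considered here, and "the series" means these few. Any claim that something is new, unique, unknown or untested is made for them only; others in the source may bear on it.

Three compounds sharing one core were measured in a functional assay on the whole organism for inhibition, with Rattus norvegicus as the target, at a dose of 30 mg/kg; on this read-out higher numbers stand for more inhibition at the one dose given (going by the name of the read-out) and lower numbers for less inhibition. Compound 1 `Brc1cccc(-c2nc3ncccc3o2)c1` gives 23%, compound 2 `COc1cccc(-c2nc3ncccc3o2)c1` gives 14%, and compound 3 `N#Cc1cccc(-c2nc3ncccc3o2)c1` gives 21%. Compound 3 thus stands second of the three, with compound 1 nearest and compound 2 furthest, though every gap is within the scatter. The step to compound 4 `c1ccc(-c2nc3ncccc3o2)cc1` is hydrogen in place of cyano on an aromatic carbon. Among the compounds with values here, no measured step removes a substituent at this position; the three that exchange one there all stay within the scatter: a number 9 percentage points lower from compound 1 to compound 2 (within the scatter), a number 2 percentage points lower from compound 1 to compound 3 (within the scatter) and a number 7 percentage points higher from compound 2 to compound 3 (within the scatter). No step beyond the scatter is therefore expected in this assay, and the expected step is a number 3 percentage points lower from compound 3 to compound 4 (within the scatter). Compound 4 is expected to give about 18%, within 4% to 34%.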

Compound 4, a percentage reported as inhibition, in the whole organism at one dose (the size of the read-out at that dose, not a potency): 41%
Compound 4: middle estimate off by 23 percentage points, on the low side; measured number above the stated range.
By their numbers in this assay, from the lowest: compounds 2, 3 and 1 (each within the scatter of the next); then compound 4.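

In this assay, hydrogen on this aromatic carbon stands apart from all three groups: replacing cyano gives (a number 20 percentage points higher from compound 3 to compound 4 (beyond the scatter)), replacing methoxy gives (a number 27 percentage points higher from compound 2 to compound 4 (beyond the scatter)), and replacing bromo gives (a number 18 percentage points higher from compound 1 to compound 4 (beyond the scatter)). Exchanging one of these groups for another stayed within the scatter, whereas removing any of them goes beyond it. Nothing measured here explains this difference. The compounds shown leave open whether any substituent at this place keeps the higher number seen with hydrogen. A fluorine atom, an amine or a carboxylic acid could each test this.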